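This account rests on a few compounds, and the source may have more. Where it says the series, first, only, none or still open, it means among the compounds named here.

Compound 1 `NC[C@@H]1CCCc2cc(S(=O)(=O)c3cccc(F)c3)ccc21`: 0.0794 nM
Compound 2 `CNS(=O)(=O)NC[C@@H]1CCCc2cc(S(=O)(=O)c3cccc(F)c3)ccc21`: 1 nM
Compound 3 `O=C(NC[C@@H]1CCCc2cc(S(=O)(=O)c3cccc(F)c3)ccc21)[C@H]1CCCN1`: 0.631 nM

These three compounds share one core and differ only in what sits on the amine nitrogen. In an assay on isolated protein for displacement of a labelled ligand from 5-hydroxytryptamine receptor 6 (Homo sapiens) (a higher number here means a weaker inhibitor, a lower number a stronger inhibitor), compound 3 gives 0.631 nM, the second highest of the three numbers; its nearest neighbour is compound 2, separated by a 1.6-fold lower number from compound 2 to compound 3 (0.20 log units; within the scatter), while compound 1 lies further off, separated by a 7.9-fold higher number from compound 1 to compound 3 (0.90 log units; beyond the scatter). Compound 4 `CN(CC(N)=O)C[C@@H]1CCCc2cc(S(=O)(=O)c3cccc(F)c3)ccc21` has not yet been measured. It differs from compound 3 by (carbamoylmethyl)(methyl)amino in place of ((pyrrolidin-2-yl)carbonyl)amino on a saturated chain carbon bound to a saturated ring carbon. The measured steps that bear on this are a 13-fold higher number from compound 1 to compound 2 (1.10 log units; beyond the scatter) and a 7.9-fold higher number from compound 1 to compound 3 (0.90 log units; beyond the scatter): both show that attaching a group to the bare amine nitrogen of compound 1 raised the number, while a 1.6-fold lower number from compound 2 to compound 3 (0.20 log units; within the scatter) shows little difference between the two groups themselves. Going by the values given here, compound 4 keeps a substituted nitrogen but no longer carries a carbonyl or a sulfonyl on it, a change no measured pair covers directly. Because the carbonyl arrived together with the rise seen in a 7.9-fold higher number from compound 1 to compound 3 (0.90 log units; beyond the scatter) and compound 4 lacks it, a modest lowering is expected, the estimated step being a 2.5-fold lower number from compound 3 to compound 4 (0.40 log units; beyond the scatter). In this assay compound 4 is expected to give 0.25 nM, with a range from 0.06 nM to 1.2 nM.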

Compound 4, inhibition constant: 1.26 nM
The estimate for compound 4 lay 5.0-fold (0.70 log units) below the measured number; the measured number lies above the stated range.
By their numbers in this assay, from the lowest: compound 1; then compounds 3, 2 and 4 (each within the scatter of the next).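

In this assay, (carbamoylmethyl)(methyl)amino on the saturated chain carbon gives a number that cannot be told apart from those of the two other substituted compounds: a 2.0-fold higher number from compound 3 to compound 4 (0.30 log units; within the scatter) and a 1.3-fold higher number from compound 2 to compound 4 (0.10 log units; within the scatter). With a 16-fold higher number from compound 1 to compound 4 (1.20 log units; beyond the scatter), the bare amino group of compound 1 still stands apart from all three substituted compounds, even when no carbonyl or sulfonyl sits directly on the nitrogen. Nothing available here gives a reason for this result.

Compound 4 carries a methyl and a carbamoylmethyl on the same nitrogen, so the share of each in that step cannot be separated. As far as these compounds go, it remains open whether a single methyl on the nitrogen would give a number near that of compound 1, and whether a carboxylic acid or a nitrile in place of the carbamoyl group would alter the number.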